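The compounds below may be only part of what the source reports. "The series", "measured", "known", "first", "only" and "open" are said of these compounds alone.

Measured compounds and their values in a functional assay on HCT-116 cells (Homo sapiens) for inhibition, read by MTT assay, with a stated time of 72 h; a lower number here means a stronger inhibitor, a higher number a weaker inhibitor:

compound 1, `CCOC(=O)c1oc2ccc(N(Cc3ccccc3)S(=O)(=O)c3ccc(C(F)(F)F)cc3)cc2c1C`, gives 26700 nM.
compound 2, `Cc1c(C(=O)O)oc2ccc(N(Cc3ccccc3)S(=O)(=O)c3ccc(Br)cc3)cc12`, gives 7090 nM.
compound 3, `Cc1c(C(=O)O)oc2ccc(N(Cc3ccccc3)S(=O)(=O)c3ccc(F)cc3)cc12`, gives only the limit > 40000 nM.

Compound 3 stands at the upper edge of what the assay reports: for it only a limit is known, not a number, whereas compound 2 gives a measured figure. Compound 4, `Cc1c(C(=O)O)oc2ccc(N(Cc3ccccc3)S(=O)(=O)c3ccc(C(F)(F)F)cc3)cc12`, differs from compound 3 in one place: trifluoromethyl in place of fluoro on an aromatic carbon. Within the data shown here, the single measured step touching the same position is an at least 5.6-fold higher number from compound 2 to compound 3 (0.75 log units; beyond the scatter), and its endpoint is the limit (the limit of > 40000 nM in this assay, at which 1 of the 3 values shown sits), so its true size is open upward. Compound 1 also carries a trifluoromethyl group, though with an ethyl ester in place of the acid, and no step between compound 1 and compound 4 is given; its value simply stands as shown. Since compound 3 sits at the limit, the step from compound 3 to compound 4 is itself expected to be read only as a bound, and the estimated step is an at least 3.3-fold lower number from compound 3 to compound 4 (0.52 log units; beyond the scatter), toward a lower number. Compound 4 is expected to give about 12000 nM, within a range of 3500 nM to 40000 nM.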

Compound 4, half-maximal inhibitory concentration: 4130 nM
Beside the measured number, compound 4's estimate is 2.9-fold (0.46 log units) above it, within the range that was stated.
By their numbers in this assay, from the lowest: compounds 4 and 2 (each within the scatter of the next); then compound 1. At a limit, above all of these: compound 3.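

In this assay, the change from 4-fluorophenyl to 4-(trifluoromethyl)phenyl gives an at least 9.6-fold lower number from compound 3 to compound 4 (0.98 log units; beyond the scatter), but this step is only a bound, as compound 3 stands at a limit: the limit of > 40000 nM in this assay, at which 1 of the 4 values shown sits.

Trifluoromethyl and bromo, by contrast, do not separate at this position, with a 1.7-fold lower number from compound 2 to compound 4 (0.23 log units; within the scatter), so among the three acids shown, fluoro alone stands apart from the other two groups. Among these compounds, the compounds also give the first reading at a second place with the trifluoromethyl group held fixed: a 6.5-fold lower number from compound 1 to compound 4 (0.81 log units; beyond the scatter), with the acid of compound 4 in place of the ethyl ester of compound 1.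

The compounds shown leave open how large the step from fluoro truly is, and whether the difference between ester and acid is of similar size when bromo or fluoro sits on the aromatic ring. They also leave open how a chloro group, a methoxy group or an amine would read at this position, and how an amide would read in place of the carboxylic acid.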